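Notes on adenosine analogues as nucleoside cotransporter inhibitors

The compounds below may be only part of what the source reports. "The series", "measured", "known", "first", "only" and "open" are said of these compounds alone.

Values so far in an assay on COS-7 cells for inhibition of sodium/nucleoside cotransporter 2 (Homo sapiens), read by scintillation counting, in the presence of a further agent that is not named here; on this read-out higher numbers stand for weaker inhibition and lower numbers for stronger inhibition:

compound 1 `Cc1ccccc1CNc1nc2c(N)ncnc2n1[C@@H]1O[C@H](CO)[C@@H](O)[C@H]1O`: 65000 nM
compound 2 `Nc1ncnc2c1ncn2[C@@H]1O[C@H](COC(=O)NCc2ccccc2)[C@@H](O)[C@H]1O`: > 100000 nM
compound 3 `Nc1ncnc2c1nc(NCc1ccc3ccccc3c1)n2[C@@H]1O[C@H](CO)[C@@H](O)[C@H]1O`: 5300 nM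

Compound 2 stands at the bottom of the series: its value is a limit of the assay, not a number, and no change from it can be read until a measured number appears. Among the measured compounds shown here, the only step measured so far, a 12-fold lower number from compound 1 to compound 3 (1.09 log units; beyond the scatter), concerns the group on a saturated chain carbon bound to a nitrogen on an aromatic ring of the shared core, and shows that swapping one aryl group for another at that place can move the read-out well beyond the scatter.

The change to compound 4 `CC(=O)OC[C@H]1O[C@@H](n2cnc3c(N)ncnc32)[C@H](O)[C@@H]1O` is methyl in place of benzylamino on a carbonyl carbon. It sits on a different part of the molecule from the measured step, so that step bears on it only as a sign that this series is sensitive to the size of pendant groups. With compound 2 at the limit of > 100000 nM in this assay, at which 1 of the 3 values shown sits, a return to a limit is the more likely outcome.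

Compound 4 is therefore expected to stay weak, with an estimated 150000 nM, range 30000 nM to 600000 nM. The expected step that the limit leaves unreadable from compound 2 to compound 4 is no change beyond the scatter.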

Compound 4, half-maximal inhibitory concentration: > 100000 nM
Compound 4: no number, only a limit (the forecaster's own chance of this, stated with the estimate: 70%); the middle value does not contradict the limit.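

Compound 2 and compound 4 both end at a limit of the assay rather than a number, so no step between them can be read: the limit of > 100000 nM in this assay, at which 2 of the 4 values shown sit.

The compounds shown leave open whether methyl in place of benzylamino on a carbonyl carbon changes the read-out at all, and how far either compound lies beyond that limit.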